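The compounds below may be only part of what the source reports. "The series", "measured", "known", "first", "only" and "open" are said of these compounds alone.

Three compounds of the series share one core and differ only in the aryl group carried at one place. Compound 1 `COc1cc(OC)c(OC)cc1/C=C/COC(=O)/C=C/c1ccc(OC)c(OC)c1OC` gives 100% in a functional assay on the whole organism (strain Kunming) with Mus musculus as the target, with a stated time of 0.5 h, at a dose of 100 mg/kg by the intraperitoneal route; on this read-out lower numbers stand for a stronger effect and higher numbers for a weaker effect at the one dose given. Compound 2 `COc1ccccc1/C=C/C(=O)OC/C=C/c1cc(OC)c(OC)cc1OC` gives 100% in this assay. Compound 3 `COc1cc(OC)c(OC)cc1/C=C/COC(=O)/C=C/c1cccc(Br)c1` gives 100% in this assay, level with compound 1 and compound 2 at the digits shown. Among the compounds with values here, the one single-place step measured so far, no change at the digits printed from compound 2 to compound 3 (within the scatter), lies within the scatter.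

Compound 4 `COc1cc(OC)c(OC)cc1/C=C/COC(=O)/C=C/c1ccc(Br)cc1` is not yet measured. It differs from compound 3 as follows: 4-bromophenyl in place of 3-bromophenyl on a double-bonded chain carbon bound to a double-bonded chain carbon. Within the data shown here, the only measured step that bears on an exchange of the aryl group at this place is no change at the digits printed from compound 2 to compound 3 (within the scatter), which moved nothing; compound 1 and compound 3 likewise stand at the same level. Nothing in the series separates the three compounds, so no step beyond the scatter is expected in this assay, and no change at the digits printed from compound 3 to compound 4 (within the scatter) is the step expected. Compound 4 is therefore estimated at 100% in this assay, with a range from 85% to 100%.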

Compound 4, a percentage reported as activity, at one dose (the size of the read-out at that dose, not a potency): 100%
The estimate for compound 4 equals the measured number at the digits printed, within the range that was stated.
By their numbers in this assay, from the lowest: compounds 1, 2, 3 and 4 (each within the scatter of the next).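

In this assay, within the data shown here, the exchange of 3-bromophenyl for 4-bromophenyl gives no change at the digits printed from compound 3 to compound 4 (within the scatter) and is the first reading at this place of the same atoms joined differently, so the change in where the bromine sits on the ring leaves the read-out level here. The exchange of 2-methoxyphenyl for 4-bromophenyl gives no change at the digits printed from compound 2 to compound 4 (within the scatter) and places this second bromophenyl group level with the 2-methoxyphenyl group as well. No measurement at hand bears on why the read-out stays level at this place.

On these data alone, all four compounds stand level in this assay, so it stays open whether any group at this place can lower the read-out at this one dose. As far as these compounds go, how a phenyl ring carrying an amine or a carboxylic acid would read here also stays open.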